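Hydrogen for Methoxy on the Aryl Group of Compound 1

This account rests on a few compounds, and the source may have more. Where it says the series, first, only, none or still open, it means among the compounds named here.

Compound 1 `COc1ccc(N2CCN(Cn3nc(-c4ccc5c(c4)OCCO5)oc3=S)CC2)cc1`: > 50000 nM
Compound 2 `COc1ccccc1N1CCN(Cn2nc(-c3ccc4c(c3)OCCO4)oc2=S)CC1`: > 50000 nM
Compound 3 `S=c1oc(-c2ccc3c(c2)OCCO3)nn1CN1CCN(c2cccc(Cl)c2)CC1`: 47200 nM

In a functional assay on HeLa cells (Homo sapiens) for antiproliferative activity, read by MTT assay, with a stated time of 48 h (a lower number here means a stronger inhibitor, a higher number a weaker inhibitor), compound 1 gives > 50000 nM, which is a limit of the assay and not a number. Compound 2 gives > 50000 nM, likewise a limit. Compound 3 gives 47200 nM. The step that the two limits leave unreadable from compound 1 to compound 2 cannot be read, and the steps of an at least 1.0-fold lower number from compound 1 to compound 3 (0.02 log units; that floor lies within the scatter) and an at least 1.0-fold lower number from compound 2 to compound 3 (0.02 log units; that floor lies within the scatter) carry only a floor that lies within the scatter. All three compounds therefore stand at or close to the limit of > 50000 nM in this assay, at which 2 of the 3 values shown sit, and compound 1 is one of those sitting at that limit.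

Compound 4 `S=c1oc(-c2ccc3c(c2)OCCO3)nn1CN1CCN(c2ccccc2)CC1` differs from compound 1 by hydrogen in place of methoxy on an aromatic carbon. For the measured compounds named here, no measured step removes the methoxy in this way; the steps that bear on it are the three exchanges of the aryl group on the same amine nitrogen in the ring, none of which moved the value beyond the scatter. A step from compound 1 to compound 4 beyond the scatter is therefore not expected, in either direction. Compound 4 is estimated at 50000 nM, with a range from 25000 nM to 100000 nM. This estimate implies an expected step of a number no higher from compound 1 to compound 4 (the limit leaves the size open).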

Compound 4, half-maximal inhibitory concentration: > 50000 nM
Compound 4: no number, only a limit; the forecaster's own chance of this, stated with the estimate: 70%; the middle value sits exactly at the limit.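

Compound 4, which carries a plain phenyl in place of the 4-methoxyphenyl, gives > 50000 nM in this assay, and this is a limit of the assay and not a number. The steps that join compound 4 to the two methoxy compounds cannot be read, and the exchange of chloro for hydrogen gives an at least 1.0-fold higher number from compound 3 to compound 4 (0.02 log units; that floor lies within the scatter). The earlier compounds only swapped one substituted aryl group for another, whereas compound 4 shows that taking the substituent off this aromatic ring altogether leaves the series where it stood: the limit of > 50000 nM in this assay, at which 3 of the 4 values shown sit.

The compounds shown leave open whether an amine or a carboxylic acid on this aromatic ring would give a value clear of the limit in this assay. They also leave open how methoxy and hydrogen compare at this position, and whether a longer chain on the amine nitrogen in place of the aryl group would move the value at all.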